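Quinolin-3-yl series: removing the methoxy from compound 2

This account rests on a few compounds, and the source may have more. Where it says the series, first, only, none or still open, it means among the compounds named here.

In a functional assay on A549 cells (Homo sapiens) for cytotoxicity, read by MTT assay, with a stated time of 48 h (a higher number here means a weaker inhibitor, a lower number a stronger inhibitor), compound 1 `COc1ccc(-c2nc3ccccn3c2C(=O)/C=C\Nc2ccc3[nH]ccc3c2)cc1` gives 11000 nM and compound 2 `COc1ccc(-c2nc3ccccn3c2C(=O)/C=C\Nc2cnc3ccccc3c2)cc1` gives 1050 nM. Compound 2 therefore holds the lower of the two numbers. Within the data shown here, the only measured step is a 10-fold lower number from compound 1 to compound 2 (1.02 log units; beyond the scatter), large and beyond the scatter, with quinolin-3-yl in place of 1H-indol-5-yl on an amine nitrogen.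

Compound 3 `O=C(/C=C\Nc1cnc2ccccc2c1)c1c(-c2ccccc2)nc2ccccn12` keeps the quinolin-3-yl and carries hydrogen in place of methoxy on an aromatic carbon, 4-methoxyphenyl to phenyl: hydrogen in place of methoxy on an aromatic carbon. The measured step concerns the amine nitrogen and sets no size for this change. Among the measured compounds shown here, no measured pair varies the methoxy.

The expected change is small and within the scatter, if anything towards a slightly higher number: a 1.4-fold higher number from compound 2 to compound 3 (0.15 log units; within the scatter). The estimate for compound 3 is 1500 nM, with an expected range of 500 nM to 5000 nM.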

Compound 3, half-maximal inhibitory concentration: 1750 nM
Beside the measured number, compound 3's estimate is 1.2-fold (0.07 log units) below it; the range from low to high includes it.
By their numbers in this assay, from the lowest: compounds 2 and 3 (each within the scatter of the next); then compound 1.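

In this assay, among these compounds, this is the first variation on the aromatic carbon that carries the methoxy, and the step reads a 1.7-fold higher number from compound 2 to compound 3 (0.22 log units; within the scatter). With the quinolin-3-yl held fixed, going from 4-methoxyphenyl to phenyl therefore stays within the scatter, so the methoxy is not required for the activity of compound 2 in this assay, while the change on the amine nitrogen gave a 10-fold lower number from compound 1 to compound 2 (1.02 log units; beyond the scatter). Nothing available explains this outcome at this position.

Among the compounds shown here, this change is seen only with the quinolin-3-yl on the amine nitrogen, so whether a 1H-indol-5-yl partner would respond in the same way stays open. Going by these compounds, how a hydroxyl, a chlorine atom or a dimethylamino group would read at this carbon also stays open.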